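The source may hold more compounds than are shown below. What is called first, only, known or untested is meant among the compounds shown, and "the series" means these compounds.

Of the compounds shown here, three from one series have been measured in a functional assay on DU-145 cells (Homo sapiens) for inhibition, read by trypan blue exclusion, with a stated time of 96 h; a lower number here means a stronger inhibitor of growth, a higher number a weaker inhibitor of growth. Compound 1, `Cc1cc(C)cc(/C=C(\C(=O)c2ccc(Cl)cc2)S(=O)(=O)c2ccc(Br)cc2)c1`, gives 10000 nM in this assay. Compound 2, `O=C(/C(=C\c1ccc(Cl)c([N+](=O)[O-])c1)S(=O)(=O)c1ccc(Br)cc1)c1ccc(Br)cc1`, gives 10000 nM in this assay, a number level with that of compound 1 at the digits shown, and together these two carry the highest numbers of the three. Compound 3, `Cc1ccc(/C=C(\C(=O)c2ccc(Cl)cc2)S(=O)(=O)Cc2ccc(Cl)cc2)s1`, gives 1000 nM in this assay, a number clearly lower than that of compound 2, and the gap lies beyond the usual scatter.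

Compound 4, `O=C(/C(=C\c1ccc(Br)c([N+](=O)[O-])c1)S(=O)(=O)c1ccc(Br)cc1)c1ccc(Br)cc1`, has not yet been measured. It is related to compound 2 by a single change: bromo in place of chloro on an aromatic carbon. Among the measured compounds shown here, the groups that leave and enter are both single halogen atoms, and no compound pair among the measured three shows what such a swap does in this assay. For the measured compounds named here, with no measured step to lean on, the expected change in this assay from compound 2 to compound 4 is small, no change at the digits printed from compound 2 to compound 4 (within the scatter), and not expected to reach beyond the scatter in either direction. Compound 4 is therefore estimated to give about 10000 nM in this assay, most likely between 4000 nM and 25000 nM.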

Compound 4, concentration for 50% growth inhibition: 10000 nM
Beside the measured number, compound 4's estimate shows no gap at the digits printed, and the stated range covers the measured number.
By their numbers in this assay, from the lowest: compound 3; then compounds 1, 2 and 4 (each within the scatter of the next).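

Bromo in place of chloro on this aromatic carbon, ortho to a nitro group, gives no change at the digits printed from compound 2 to compound 4 (within the scatter) in this assay. Among the compounds shown here, this is the first one-place step, and it shows that, in this pair, the 4-chloro-3-nitrophenyl and 4-bromo-3-nitrophenyl groups cannot be told apart by this read-out. Nothing available explains why the two halogens read alike.

On these data alone, whether a different kind of group at this carbon, such as an amine, a methoxy group or a carboxylic acid, would shift the number remains open. Also open, as far as these compounds go, is whether the same halogen swap would read alike without the nitro group, or on a compound with a much lower number in this assay.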